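The compounds below may be only part of what the source reports. "The series", "measured", "known", "first", "only" and "open" are said of these compounds alone.

Measured in a functional assay on PC-3 cells (Homo sapiens) for inhibition, read by MTT assay, with a stated time of 48 h; on this read-out higher numbers stand for weaker inhibition and lower numbers for stronger inhibition:
Compound 1 `COc1ccc(-c2coc3cc(OCCCSC(=S)N4CCN(C)CC4)ccc3c2=O)cc1`: 2210 nM
Compound 2 `CCN1CCN(C(=S)SCCCOc2ccc3c(=O)c(-c4ccc(OC)cc4)coc3c2)CC1`: 7080 nM
Compound 3 `COc1ccc(-c2coc3cc(OCCCCCBr)ccc3c2=O)cc1`: 44800 nM

Compound 3 carries the highest number of the three, and its gaps to the other two lie beyond the scatter. The record shows a 6.3-fold higher number from compound 2 to compound 3 (0.80 log units; beyond the scatter) and a 20-fold higher number from compound 1 to compound 3 (1.31 log units; beyond the scatter).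

Compound 4 `COc1ccc(-c2coc3cc(OCCCCBr)ccc3c2=O)cc1` has not yet been measured. It differs from compound 3 by a single change at the end of the chain: bromo in place of bromomethyl on a saturated chain carbon, four bonds along the chain from an oxygen on an aromatic ring. In words, this is bromo in place of bromomethyl on a saturated chain carbon, four bonds along the chain from an oxygen on an aromatic ring.

Among the measured compounds shown here, no measured step makes this same change. The two steps into compound 3 exchange the whole group at the chain end, so they say little about so small an edit. For the measured compounds named here, the only measured step that adds a single methyl is a 3.2-fold higher number from compound 1 to compound 2 (0.51 log units; beyond the scatter), and it lies at a different place in the molecule. The data give no direction for the change. In this assay, a step no larger than that one is therefore expected, and quite possibly none beyond the scatter.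

The expected step is a 1.3-fold lower number from compound 3 to compound 4 (0.11 log units; within the scatter). For compound 4 the estimate is 35000 nM, with an expected range from 12000 nM to 90000 nM.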

Compound 4, half-maximal inhibitory concentration: 55600 nM
Compound 4: the middle estimate sits 1.6-fold (0.20 log units) below what was measured; low and high end bracket the measured number.
By their numbers in this assay, from the lowest: compound 1; then compound 2; then compounds 3 and 4 (each within the scatter of the next).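

In this assay, replacing bromomethyl with bromo on a saturated chain carbon, four bonds along the chain from an oxygen on an aromatic ring, gives a 1.2-fold higher number from compound 3 to compound 4 (0.09 log units; within the scatter), so this small edit at the chain end produces no change that can be told from the scatter. The wide gap to the compounds with the six-membered ring at the chain end remains with this bromo compound, which shows a 7.9-fold higher number from compound 2 to compound 4 (0.90 log units; beyond the scatter) and a 25-fold higher number from compound 1 to compound 4 (1.40 log units; beyond the scatter), so among these four compounds, the two bromo compounds sit together and well apart from compounds 1 and 2. Nothing available here explains either the flat step between the two bromo compounds or the gap to the ring-bearing compounds.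

The compounds shown leave open whether the flat step holds only with bromo at the chain end, or whether a chain ending in an amine or a hydroxyl would also respond so little to the same shortening. They also leave open whether a still longer chain, or the same change in chain length in compounds carrying the ring-bearing end group of compound 1, would move the number beyond the scatter.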